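Hydroxy for trifluoromethoxy on the pendant aryl ring

This account rests on a few compounds, and the source may have more. Where it says the series, first, only, none or still open, it means among the compounds named here.

Measured compounds, all in a functional assay on HepG2 cells (Homo sapiens) for antiproliferative activity, read by MTT assay, with a stated time of 48 h; a lower number here means a stronger inhibitor, a higher number a weaker inhibitor:
Compound 1 `COc1ccc(CN2C(=O)C(=O)c3cc(-c4ccc(Cl)cc4)ccc32)cc1` gives 380 nM.
Compound 2 `COc1ccc(CN2C(=O)C(=O)c3cc(-c4ccc(C)cc4)ccc32)cc1` gives > 10000 nM, which is a limit of the assay and not a number.
Compound 3 `COc1ccc(CN2C(=O)C(=O)c3cc(-c4ccc(OC(F)(F)F)cc4)ccc32)cc1` gives 410 nM.

Compound 3 and compound 1 sit within the scatter of each other, as a 1.1-fold higher number from compound 1 to compound 3 (0.03 log units; within the scatter) shows. Compound 2 sits at the limit (the limit of > 10000 nM in this assay, at which 1 of the 3 values shown sits). Compound 4 `COc1ccc(CN2C(=O)C(=O)c3cc(-c4ccc(O)cc4)ccc32)cc1` has not yet been measured; it differs from compound 3 by hydrogen in place of trifluoromethyl on an oxygen on an aromatic ring. Going by the values given here, no measured step involves a hydroxy group, so nothing speaks directly to this change. Among the compounds with values here, the steps that bear on substitution at this place are an at least 26-fold higher number from compound 1 to compound 2 (1.42 log units; beyond the scatter) and an at least 24-fold lower number from compound 2 to compound 3 (1.38 log units; beyond the scatter), both large, which show that what sits on this ring can move the number far. Within the data shown here, a step beyond the scatter is therefore expected in this assay, and with no closer precedent the direction is uncertain; a loss is taken as the more likely outcome. Compound 4 is estimated at 3000 nM, in a range from 500 nM to 15000 nM. This estimate means a step of a 7.3-fold higher number from compound 3 to compound 4 (0.86 log units; beyond the scatter).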

Compound 4, half-maximal inhibitory concentration: > 10000 nM
Compound 4 was reported as a limit (the forecaster's own chance of this, stated with the estimate: 35%); at least 3.3-fold (0.52 log units) between middle value and limit.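

Hydrogen in place of trifluoromethyl on the oxygen brings an at least 24-fold higher number from compound 3 to compound 4 (1.38 log units; beyond the scatter) in this assay, and hydroxy in place of chloro brings an at least 26-fold higher number from compound 1 to compound 4 (1.42 log units; beyond the scatter). Going by these compounds alone, until now only methyl had led to such a loss at this place, so hydroxy is a second group that does so, while chloro and trifluoromethoxy remain the only groups here with a readable number. Compound 2 and compound 4 both stand at a limit, so the step between them cannot be read and hydroxy and methyl cannot be ordered: the limit of > 10000 nM in this assay, at which 2 of the 4 values shown sit.

The compounds shown leave open whether an amine or a carboxylic acid at this place would match compound 1 and compound 3 or also end at the limit. They also leave open how a methoxy group on this ring would compare with trifluoromethoxy and hydroxy.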